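The source may hold more compounds than are shown below. What is called first, only, known or untested is meant among the compounds shown, and "the series" means these compounds.

Series notes. Within the data shown here, compound 3 `Cc1cc(/C=C/C#N)cc(C)c1Oc1cc(Nc2ccc(C#N)cc2)c(N)cc1C(=O)N1CC1` gives 2.21 in a physicochemical assay for lipophilicity, read by HPLC, measured as octanol-water partition, with a stated time of 24 h, at pH 7.4 (on this read-out lower numbers stand for lower lipophilicity and higher numbers for higher lipophilicity), the lowest of the three numbers measured so far. Compound 1 `Cc1cc(/C=C/C#N)cc(C)c1Oc1cc(Nc2ccc(C#N)cc2)c(N)cc1C(=O)NCCCO` gives 3.22 in this assay, and compound 2 `Cc1cc(/C=C/C#N)cc(C)c1Oc1cc(Nc2ccc(C#N)cc2)c(N)cc1C(=O)NCCC(F)F` gives 3.58. Both steps onto compound 3 were large: a number 1.01 log units lower from compound 1 to compound 3 (beyond the scatter) and a number 1.37 log units lower from compound 2 to compound 3 (beyond the scatter). The step between the two chain amides was modest, a number 0.36 log units higher from compound 1 to compound 2 (beyond the scatter).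

Compound 4 `COC(=O)c1cc(N)c(Nc2ccc(C#N)cc2)cc1Oc1c(C)cc(/C=C/C#N)cc1C` differs from compound 3 by methoxy in place of aziridin-1-yl on a carbonyl carbon. Among the measured compounds shown here, no measured step exchanges a group on the carbonyl carbon for methoxy, so the measured steps bear on this change only indirectly: every measured exchange of the group on the carbonyl carbon moved this assay by a large amount, and the aziridin-1-yl compound sits well under the two chain amides. On that basis a step upward beyond the scatter is expected from compound 3 to compound 4, a number 0.89 log units higher from compound 3 to compound 4 (beyond the scatter), though its size is uncertain. For compound 4 the expected value in this assay is 3.1, with a range from 2.4 to 3.8.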

Compound 4, partition coefficient: 4.15
For compound 4 the middle estimate is 1.05 log units below the measured one; the whole stated range lies below it.
By their numbers in this assay, from the lowest: compound 3; then compound 1; then compound 2; then compound 4.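

Methoxy on the carbonyl carbon gives the highest number of the series in this assay, with a number 1.94 log units higher from compound 3 to compound 4 (beyond the scatter), so this position can carry a far wider spread than the chain amides and aziridin-1-yl showed. The methoxy compound also stands clear of both chain amides, with a number 0.57 log units higher from compound 2 to compound 4 (beyond the scatter) and a number 0.93 log units higher from compound 1 to compound 4 (beyond the scatter). Aziridin-1-yl and methoxy are both counted with 0 hydrogen-bond donors yet mark the two ends of the series, so that count alone does not order these compounds, and nothing at hand accounts for the size of these steps.

Still open, as far as these compounds go, is whether the low number of compound 3 goes with the three-membered ring, which a pyrrolidin-1-yl group on the carbonyl carbon would test. Also open, from the compounds shown here alone, is how ethoxy or a carboxylic acid would stand against methoxy here.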